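Aryl amide swap on a benzamide-capped linker

This account rests on a few compounds, and the source may have more. Where it says the series, first, only, none or still open, it means among the compounds named here.

Measured compounds:
compound 1, `COc1ccc(NC(=O)CNCCCC(=O)Nc2ccccc2N)cc1`: 8600 nM
compound 2, `Nc1ccccc1NC(=O)CCCNCC(=O)Nc1cc(Cl)ccc1Cl`: 31000 nM

Compound 2 gives the higher of the two numbers in a functional assay on HCT-116 cells (Homo sapiens) for inhibition, read by MTT assay, with a stated time of 2 days; a lower number here means a stronger inhibitor of growth, a higher number a weaker inhibitor of growth; its nearest neighbour is compound 1, reached by a 3.6-fold higher number from compound 1 to compound 2 (0.56 log units; beyond the scatter), a step that lies beyond the scatter. Compound 3, `Nc1ccccc1NC(=O)CCCNCC(=O)Nc1ccc(Br)cc1`, has not been measured yet. It differs from compound 2 in one place: 4-bromophenyl in place of 2,5-dichlorophenyl on an amide-type nitrogen. Going by the values given here, the only step that bears on this change is the one from compound 1 to compound 2, where the aryl group on the same amide-type nitrogen was exchanged and the number moved modestly upward. Since 4-bromophenyl shares neither the two chlorine atoms of compound 2 nor the methoxy group of compound 1, the direction is uncertain, but compound 3 is expected to fall between the two, so a 2.2-fold lower number from compound 2 to compound 3 (0.35 log units; beyond the scatter) is expected to be a modest move downward. The estimate for compound 3 in this assay is 14000 nM, with a range from 5000 nM to 35000 nM.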

Compound 3, concentration for 50% growth inhibition: 7700 nM
The estimate for compound 3 lay 1.8-fold (0.26 log units) above the measured number; low and high end bracket the measured number.
By their numbers in this assay, from the lowest: compounds 3 and 1 (each within the scatter of the next); then compound 2.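

In this assay, the aryl group on the amide-type nitrogen can move the number in either direction: the earlier rise is matched by a fall, with a 4.0-fold lower number from compound 2 to compound 3 (0.60 log units; beyond the scatter). The change of substituent alone does not always register, however, as a 1.1-fold lower number from compound 1 to compound 3 (0.05 log units; within the scatter) leaves compound 1 and compound 3 indistinguishable, and compound 2 alone stands apart from the other two. Nothing measured here offers an explanation for this separation.

What the compounds shown leave open is whether the separation of compound 2 follows from carrying two chlorine atoms or from where they sit, and whether a 4-chlorophenyl group would read with compound 3 or with compound 2. They also leave open how an amine or a carboxylic acid on this aryl ring, or a longer chain in the linker, would read.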